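Enlarging the Ether Ring on the Triazole Nitrogen

The source may hold more compounds than are shown below. What is called first, only, known or untested is meant among the compounds shown, and "the series" means these compounds.

Compound 2 `Fc1ccc(-c2noc(C3CCc4c(nnn4C4CCOC4)C3)n2)cc1` stands on a single number in a functional assay on U2OS cells for positive allosteric modulation of metabotropic glutamate receptor 5 (Homo sapiens), read by calcium flux, in the presence of a further agent that is not named here; a higher number here means that more compound is needed for the effect, a lower number that less compound is needed: compound 2 gives 398 nM, and one further entry yields no single number. Compound 1 `Fc1ccc(-c2noc(C3CCc4c(nnn4C4CCCC4)C3)n2)cc1`, measured in the same way, shows scattered values: compound 1 gives 398 nM; 31.6 nM (2 entries), (the several entries of compound 1 in this assay, 398 nM; 31.6 nM (2 entries)). Compound 3 `CC1(n2nnc3c2CCC(c2nc(-c4ccc(F)cc4)no2)C3)CCOCC1` differs from compound 2 by 4-methyloxan-4-yl in place of oxolan-3-yl on an aromatic nitrogen. No measured step of this kind is shown, so the change is expected to bring no shift beyond the usual scatter, a 1.3-fold lower number from compound 2 to compound 3 (0.12 log units; within the scatter). Compound 3 is therefore estimated at 300 nM, within a range from 60 nM to 1500 nM.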

Compound 3, half-maximal effective concentration: 10 nM
Compound 3: middle estimate off by 30-fold (1.48 log units), on the high side; measured number below the stated range.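

Exchanging oxolan-3-yl for 4-methyloxan-4-yl on the aromatic nitrogen gives a 40-fold lower number from compound 2 to compound 3 (1.60 log units; beyond the scatter) in this assay, so the group at this position can move the number well beyond the scatter. The step rests on a single number for compound 2, and repeated entries can spread widely, as compound 1 shows: the several entries of compound 1 in this assay, 398 nM; 31.6 nM (2 entries).

The change brings in a six-membered ring and the methyl together, and the compounds shown cannot separate the two. Plain oxan-4-yl would address that, while piperidin-4-yl, with an amine nitrogen in place of the ring oxygen, would test whether that oxygen matters.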